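From (Ethylcarbamoyl)amino to 2-Oxoimidazolidin-1-yl

This account rests on a few compounds, and the source may have more. Where it says the series, first, only, none or still open, it means among the compounds named here.

Compound 1 `CCNC(=O)Nc1ccc(/C=C\c2cc(OC)c(OC)c(OC)c2)cc1`: 21000 nM
Compound 2 `CCNC(=O)Nc1ccc(/C=C/c2cccc(Cl)c2)cc1`: > 20000 nM
Compound 3 `CCNC(=O)Nc1ccc(/C=C/c2cc(C)cc(C)c2)cc1`: > 20000 nM

These values come from a functional assay on M21 cells (Homo sapiens) for inhibition, read by sulforhodamine B assay, with a stated time of 48 h; a lower number here means a stronger inhibitor, a higher number a weaker inhibitor. For compound 3 the value is only a limit of the assay, > 20000 nM, not a number. It shares this position with one other compound, as the limit of > 20000 nM in this assay, at which 2 of the 3 values shown sit, shows. Compound 4 `Cc1cc(C)cc(/C=C/c2ccc(N3CCNC3=O)cc2)c1` differs from compound 3 in one place: 2-oxoimidazolidin-1-yl in place of (ethylcarbamoyl)amino on an aromatic carbon. Within the data shown here, no measured pair here shows what such a swap does, so the size of the step in this assay cannot be read from the data. Given that compound 3 sits at > 20000 nM, compound 4 is expected to remain weak, with a step that the limit leaves unreadable from compound 3 to compound 4. Compound 4 is therefore estimated at 25000 nM, with a range from 8000 nM to 80000 nM.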

Compound 4, half-maximal inhibitory concentration: 17000 nM
Estimate against measurement, compound 4: 1.5-fold (0.17 log units) above; the range from low to high includes it.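

With 2-oxoimidazolidin-1-yl in place of (ethylcarbamoyl)amino, this assay shows an at least 1.1-fold lower number from compound 3 to compound 4 (0.07 log units; that floor lies within the scatter). Compound 4 gives a real number, 17000 nM, so this position can carry the ring and still be read in the assay's range. The true size of the step remains unknown because compound 3 has only a limit: the limit of > 20000 nM in this assay, at which 2 of the 4 values shown sit.

Going by these compounds, whether the same swap would act alike on the cores of compound 1 and compound 2 stays open. So does what a simple amine or a carboxylic acid would do at this place.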